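A few compounds are considered here, and "the series" means these few. Any claim that something is new, unique, unknown or untested is made for them only; others in the source may bear on it.

Measured in a functional assay on G-361 cells (Homo sapiens) for cytotoxicity, read by fluorescence, with a stated time of 72 h; a higher number here means a weaker inhibitor, a lower number a stronger inhibitor:
- compound 1 `CC(C)c1n[nH]c2c(NCc3ccc(-c4ccccn4)cc3)nc(S(C)(=O)=O)nc12`: 793 nM
- compound 2 `CC(C)c1n[nH]c2c(NCc3ccc(-c4ccccn4)cc3)nc(NCCN(C)C)nc12`: 640 nM

Going by the values given here, on these numbers, compound 2 cannot be separated from compound 1, the only other measured compound. Compound 3 `CC(C)c1n[nH]c2c(NCc3ccc(-c4ccccn4)cc3)nc(N[C@H]3CC[C@H](N)CC3)nc12` is not yet measured. It carries 4-aminocyclohexyl in place of 2-(dimethylamino)ethyl on a nitrogen on an aromatic ring. Among the compounds with values here, only one measured step bears on this change, and only indirectly, since it replaced methylsulfonyl with (2-(dimethylamino)ethyl)amino rather than altering the group now in question. That step was a 1.2-fold lower number from compound 1 to compound 2 (0.09 log units; within the scatter). Within the data shown here, the data hold no direct precedent for the cyclohexyl ring, so in this assay no clear move beyond the scatter is expected, with a slight lean towards a lower number as a matter of judgement. The expected change is a 1.6-fold lower number from compound 2 to compound 3 (0.20 log units; within the scatter). For compound 3 the estimated value is 400 nM, with an expected range of 90 nM to 1300 nM.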

Compound 3, half-maximal inhibitory concentration: 745 nM
For compound 3 the middle estimate is 1.9-fold (0.27 log units) below the measured one; measured number inside the range.
By their numbers in this assay, from the lowest: compounds 2, 3 and 1 (each within the scatter of the next).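

In this assay, 4-aminocyclohexyl in place of 2-(dimethylamino)ethyl on a nitrogen on an aromatic ring gives a 1.2-fold higher number from compound 2 to compound 3 (0.07 log units; within the scatter), so the open chain and the six-membered non-aromatic ring of carbon only cannot be told apart here, even with 2 defined stereocentres entering. Measured against the methylsulfonyl compound, (4-aminocyclohexyl)amino gives a 1.1-fold lower number from compound 1 to compound 3 (0.03 log units; within the scatter), so this second amino group also fails to separate from methylsulfonyl at this place, and all three compounds now sit within the scatter of one another. Nothing available offers a reason for this closeness.

Going by these compounds, it remains open whether a plain cyclohexyl without its amine, a carboxylic acid or a longer chain on this nitrogen would move the number beyond the scatter. The compounds shown also leave open whether any group at this place matters in this assay at all.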